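Removing One Methoxy Group from Compound 2

A few compounds are considered here, and "the series" means these few. Any claim that something is new, unique, unknown or untested is made for them only; others in the source may bear on it.

Compound 1 `COc1ccc(-c2cc(/C=C/C(=O)c3ccc(N)cc3)[nH]n2)cc1`: -40%
Compound 2 `COc1cc(-c2cc(/C=C/C(=O)c3ccc(N)cc3)[nH]n2)cc(OC)c1OC`: -32%
Compound 3 `COc1cc(-c2cc(/C=C/C(=O)c3ccc(Cl)c(Cl)c3)[nH]n2)cc(OC)c1OC`: 31%

These values come from a functional assay on NCI-H460 cells (Homo sapiens) for cytotoxicity, read by sulforhodamine B assay, with a stated time of 48 h, tested at 10 uM; on this read-out lower numbers stand for a stronger effect and higher numbers for a weaker effect at the one concentration tested. Among the three numbers compound 2 stands second highest: compound 1 lies a little lower, within the usual scatter, while compound 3 lies far higher. Compound 4 `COc1ccc(-c2cc(/C=C/C(=O)c3ccc(N)cc3)[nH]n2)cc1OC` differs from compound 2 in a single place: hydrogen in place of methoxy on an aromatic carbon. Within the data shown here, the only measured single step, a number 63 percentage points higher from compound 2 to compound 3 (beyond the scatter), changes the group on the carbonyl carbon and so does not bear on this site. Compound 1 and compound 2, which differ only in methoxy groups on the same ring, give values within the scatter of each other, so no step beyond the scatter is expected here. Compound 4 is therefore estimated at -35%, with a range from -55% to -12%. This means an expected step of a number 3 percentage points lower from compound 2 to compound 4 (within the scatter).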

Compound 4, a percentage reported as activity, at one concentration (the size of the read-out at that concentration, not a potency): -49%
For compound 4 the middle estimate is 14 percentage points above the measured one; the measured number falls inside the stated range.
By their numbers in this assay, from the lowest: compounds 4, 1 and 2 (each within the scatter of the next, the first and the last beyond it); then compound 3.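

Replacing this methoxy with hydrogen gives a number 17 percentage points lower from compound 2 to compound 4 (beyond the scatter) in this assay and so shows that this ring carbon can change the read-out. A methoxy in place of hydrogen on the same ring gives a number 9 percentage points lower from compound 1 to compound 4 (within the scatter) in this assay and shows no clear change for that single addition. The effect of a methoxy on this ring therefore depends on which other methoxy groups are present. No measurement here explains this difference. From the compounds shown here alone, how a fluorine atom or an ethoxy group would behave at this carbon remains open.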